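The compounds below may be only part of what the source reports. "The series", "measured", "known", "first", "only" and "open" are said of these compounds alone.

Measured so far in an assay on isolated protein for inhibition of Leucine-rich repeat serine/threonine-protein kinase 2 (Homo sapiens), in the presence of a further agent that is not named here; on this read-out higher numbers stand for weaker inhibition and lower numbers for stronger inhibition:
compound 1 `COc1ccc(OC)c(Sc2ccc3nnc(-c4ccccc4)n3n2)c1`, 173 nM
compound 2 `COc1ccc(OC)c(Sc2ccc3nnc(-c4cccnc4)n3n2)c1`, 242 nM
compound 3 `COc1ccc(OC)c(Sc2ccc3nnc(-c4ccn(C)n4)n3n2)c1`, 224 nM

Compound 1 holds the lowest of the three numbers, yet both neighbours sit within the scatter of it, so no order among the three can be read. Compound 4 `COc1ccc(OC)c(Sc2ccc3nnc(-c4cn(C)nc4C)n3n2)c1` differs from compound 1 by 1,3-dimethyl-1H-pyrazol-4-yl in place of phenyl on an aromatic carbon. Among the compounds with values here, the steps that bear on this are a 1.4-fold higher number from compound 1 to compound 2 (0.15 log units; within the scatter) and a 1.3-fold higher number from compound 1 to compound 3 (0.11 log units; within the scatter), each within the scatter; compound 3 is the nearest precedent, with its own five-membered ring carrying two nitrogens at the same place. Swapping the phenyl for another small heteroaryl has so far moved nothing beyond the scatter, so for compound 4 the expected step is a 1.4-fold higher number from compound 1 to compound 4 (0.16 log units; within the scatter). Compound 4 is accordingly estimated at 250 nM, with a range of 120 nM to 600 nM.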

Compound 4, half-maximal inhibitory concentration: 323 nM
Compound 4: the middle estimate sits 1.3-fold (0.11 log units) below what was measured, and the stated range covers the measured number.
By their numbers in this assay, from the lowest: compounds 1, 3, 2 and 4 (each within the scatter of the next).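

In this assay, 1,3-dimethyl-1H-pyrazol-4-yl on this aromatic carbon gives a 1.9-fold higher number from compound 1 to compound 4 (0.27 log units; within the scatter), a 1.4-fold higher number from compound 3 to compound 4 (0.16 log units; within the scatter) and a 1.3-fold higher number from compound 2 to compound 4 (0.13 log units; within the scatter). The place between two ring nitrogen atoms thus accepts a fourth aromatic group, here a methylated five-membered ring with more heavy atoms than phenyl, with no step beyond the scatter. Nothing available gives a reason for these numbers.

On these data alone, whether any group at this carbon moves the number beyond the scatter stays open. A morpholine, a carboxylic acid or a longer alkyl chain there would put that to the test.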